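Carboxy in place of amino: notes on compound 4

A few compounds are considered here, and "the series" means these few. Any claim that something is new, unique, unknown or untested is made for them only; others in the source may bear on it.

Measured in a functional assay on A549 cells (Homo sapiens) for antiproliferative activity, read by MTT assay, with a stated time of 48 h; on this read-out higher numbers stand for weaker inhibition and lower numbers for stronger inhibition:
- compound 1 `COc1ccc(-c2cc3c(cn2)[nH]c(=O)n3-c2cc(OC)c(OC)c(OC)c2)cc1O` gives 630 nM
- compound 2 `COc1ccc(-c2cc3c(cn2)[nH]c(=O)n3-c2cc(OC)c(OC)c(OC)c2)cn1` gives 1220 nM
- compound 3 `COc1ccc(-c2cc3c(cn2)[nH]c(=O)n3-c2cc(OC)c(OC)c(OC)c2)cc1N` gives 1140 nM

Compound 3 cannot be separated from the other two measured compounds: the data show a 1.8-fold higher number from compound 1 to compound 3 (0.26 log units; within the scatter) and a 1.1-fold lower number from compound 2 to compound 3 (0.03 log units; within the scatter). Compound 4 `COc1ccc(-c2cc3c(cn2)[nH]c(=O)n3-c2cc(OC)c(OC)c(OC)c2)cc1C(=O)O` is still unmeasured. It carries carboxy in place of amino on an aromatic carbon, ortho to a methoxy group and meta to a large group: carboxy in place of amino on an aromatic carbon.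

Two further comparisons bear on this change. Hydroxy and amino differ by the step from compound 1 to compound 3 given above, and the aryl swap gives a 1.9-fold higher number from compound 1 to compound 2 (0.29 log units; within the scatter). All of these steps stay within the scatter, but none involves a carboxy group, so the direction rests on little evidence. A modest move to a higher number is expected in this assay, with a wide range. The expected result is a 2.2-fold higher number from compound 3 to compound 4 (0.34 log units; beyond the scatter). For compound 4 the estimated value is 2500 nM, with an expected range of 800 nM to 10000 nM.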

Compound 4, half-maximal inhibitory concentration: 1280 nM
Estimate against measurement, compound 4: 2.0-fold (0.29 log units) above; low and high end bracket the measured number.
By their numbers in this assay, from the lowest: compounds 1, 3, 2 and 4 (each within the scatter of the next, the first and the last beyond it).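

In this assay, carboxy at this position, ortho to a methoxy group, cannot be separated from amino (a 1.1-fold higher number from compound 3 to compound 4 (0.05 log units; within the scatter)), and the 3-carboxy-4-methoxyphenyl group cannot be separated from 6-methoxypyridin-3-yl (a 1.0-fold higher number from compound 2 to compound 4 (0.02 log units; within the scatter)). Among these compounds, the one step here that lies beyond the scatter is the modest one between carboxy and hydroxy (a 2.0-fold higher number from compound 1 to compound 4 (0.31 log units; beyond the scatter)), whereas the step between amino and hydroxy stayed within it. No measurement at hand explains this separation.

Going by these compounds, it remains open whether a methyl ester or a primary amide at this position would read like compound 4 or like compound 1. A longer chain ending in a carboxylic acid, or a plain methyl group here, also remains untested in the compounds shown.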